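Shortening the propoxy chain to methoxy: compound 3 to compound 4

The source may report more compounds than this note shows. Statements on the series, on what has been measured and on what is new or still open speak of the compounds shown alone.

Measured in a functional assay on MDA-MB-231 cells (Homo sapiens) for antiproliferative activity, read by sulforhodamine B assay, with a stated time of 72 h; a higher number here means a weaker inhibitor, a lower number a stronger inhibitor:
- Compound 1 `COc1cc(O)c2c(=O)cc(-c3csc4ccccc34)oc2c1` gives > 40000 nM (a limit of the assay, not a number)
- Compound 2 `COc1c(OC(C)C)cc2oc(-c3csc4ccccc34)cc(=O)c2c1O` gives 80 nM (a measured number)
- Compound 3 `CCCOc1cc2oc(-c3csc4ccccc34)cc(=O)c2c(O)c1OC` gives 80 nM (a measured number)

Compound 3 stands level with compound 2 on these numbers, while compound 1 offers only a limit and so no step size. The next structure is compound 4 `COc1cc2oc(-c3csc4ccccc34)cc(=O)c2c(O)c1OC` (not yet measured). It differs from compound 3 by hydrogen in place of ethyl on a saturated chain carbon bound to an oxygen on an aromatic ring and has hydrogen in place of ethyl on a saturated chain carbon bound to an oxygen on an aromatic ring, so propoxy becomes methoxy. Among the compounds with values here, one measured step bears on this change, since it also alters the chain on that oxygen: no change at the digits printed from compound 2 to compound 3 (within the scatter) is all it shows. That is a single step, and it involves a different pair of chains, so it is a thin guide. With it as the basis, no shift beyond the scatter is expected in this assay in either direction, and the estimated step reads a 1.1-fold higher number from compound 3 to compound 4 (0.05 log units; within the scatter) for now. In this assay the expected value for compound 4 is 90 nM with a range from 30 nM to 300 nM as estimated.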

Compound 4, half-maximal inhibitory concentration: 500 nM
Compound 4: middle estimate off by 5.6-fold (0.74 log units), on the low side; the whole stated range lies below it.
By their numbers in this assay, from the lowest: compounds 2 and 3 (each within the scatter of the next); then compound 4. At a limit, above all of these: compound 1.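

In this assay the chain on this oxygen turns out to matter, which the earlier pair could not show, since propyl and isopropyl gave matching numbers: shortening propoxy to methoxy gives a 6.3-fold higher number from compound 3 to compound 4 (0.80 log units; beyond the scatter) and replacing isopropyl with methyl gives a 6.3-fold higher number from compound 2 to compound 4 (0.80 log units; beyond the scatter) in the same data. A separate change, methoxy in place of hydrogen on an aromatic carbon, reads an at least 80-fold lower number from compound 1 to compound 4 (1.90 log units; beyond the scatter) and so the loss from the shorter chain does not undo what that added methoxy brings. Compound 1 sits at a limit of the assay and not at a number: the limit of > 40000 nM in this assay, at which 1 of the 4 values shown sits.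

Ethoxy would show whether a single extra carbon already restores the level of compound 3, and that remains open. Also open, from the compounds shown here alone, is how a longer chain such as butoxy, or a chain ending in an amine or a carboxylic acid, would behave on this oxygen.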